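From a Phenyl to a Pyridine at the Limit

The source may hold more compounds than are shown below. What is called first, only, known or untested is meant among the compounds shown, and "the series" means these compounds.

In a functional assay on MCF7 cells (Homo sapiens) for antiproliferative activity, read by MTT assay, with a stated time of 72 h (on this read-out higher numbers stand for weaker inhibition and lower numbers for stronger inhibition), compound 1 `C=CC(=O)Nc1cccc(Oc2nc(Nc3ccc(OC)cc3)nc3c2CSCC3)c1` gives 11700 nM, and compound 2 `CC/C=C/C(=O)Nc1cccc(Oc2nc(Nc3ccc(OC)cc3)nc3c2CSCC3)c1` gives 31400 nM. Compound 3 `COc1ccc(Nc2nc3c(c(Oc4cccc(NC(=O)C=C(C)C)c4)n2)CSCC3)cc1` has no number, only a limit of the assay, > 50000 nM. Compound 4 `COc1ccc(Nc2nc3c(c(Oc4cccc(NC(=O)C=C(C)C)c4)n2)CSCC3)cn1` carries 6-methoxypyridin-3-yl in place of 4-methoxyphenyl on a nitrogen on an aromatic ring. The measured steps, a 2.7-fold higher number from compound 1 to compound 2 (0.43 log units; beyond the scatter) and an at least 4.2-fold higher number from compound 1 to compound 3 (0.63 log units; beyond the scatter), change only the group on the carbonyl carbon, so none of them tests this exchange. No step beyond the scatter is therefore expected in this assay, and the estimated step is a number no higher from compound 3 to compound 4 (the limit leaves the size open). Compound 4 is expected at about 50000 nM, with an estimated range from 18000 nM to 90000 nM.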

Compound 4, half-maximal inhibitory concentration: 22200 nM
Estimate against measurement, compound 4: 2.3-fold (0.35 log units) above; the measured number falls inside the stated range.
By their numbers in this assay, from the lowest: compounds 1, 4 and 2 (each within the scatter of the next, the first and the last beyond it). At a limit, above all of these: compound 3.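

In this assay, going by these compounds alone, 6-methoxypyridin-3-yl in place of 4-methoxyphenyl on the nitrogen gives an at least 2.2-fold lower number from compound 3 to compound 4 (0.35 log units; beyond the scatter), the first measured change at this place, since the earlier compounds differ only in the group on the carbonyl carbon. Compound 3 has only a limit of the assay, so this step has a floor and no exact size: the limit of > 50000 nM in this assay, at which 1 of the 4 values shown sits.

From the compounds shown here alone, whether 6-methoxypyridin-3-yl would lower the numbers of compound 1 and compound 2 as well remains open. So does the outcome with an amine or a longer alkoxy chain in place of the methoxy.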